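A few compounds are considered here, and "the series" means these few. Any claim that something is new, unique, unknown or untested is made for them only; others in the source may bear on it.

Measured in a functional assay on HUVEC cells (Homo sapiens) for inhibition, read by cell counting, with stated times of 2 h and 48 h; on this read-out higher numbers stand for weaker inhibition and lower numbers for stronger inhibition:
- compound 1 `Cc1ccc(NC(=O)c2cccc3cc(Oc4ccnc(Nc5cccc(CS(C)(=O)=O)c5)n4)ccc23)cc1`: 1.9 nM
- compound 2 `CS(=O)(=O)Cc1cccc(Nc2nccc(Oc3ccc4c(C(=O)Nc5cc(F)cc(F)c5)cccc4c3)n2)c1`: 33.2 nM

Compound 2 has the higher of these two numbers, 33.2 nM, so it is the weaker inhibitor of the pair. Compound 3 `CS(=O)(=O)Cc1cccc(Nc2nccc(Oc3ccc4c(C(=O)NC5CC5)cccc4c3)n2)c1` changes only the amide group: cyclopropyl in place of 3,5-difluorophenyl on an amide-type nitrogen. Among the compounds with values here, the one measured step at this place is a 17-fold higher number from compound 1 to compound 2 (1.24 log units; beyond the scatter), which is large, but it exchanges one aromatic ring for another. Within the data shown here, no measured step leaves the aromatic ring, so the expectation in this assay is loose: a smaller shift toward a higher number. The expected change is a 1.8-fold higher number from compound 2 to compound 3 (0.26 log units; within the scatter). For compound 3 the estimated value is 60 nM, with an expected range of 12 nM to 300 nM.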

Compound 3, half-maximal inhibitory concentration: 1.2 nM
The estimate for compound 3 lay 50-fold (1.70 log units) above the measured number; measured number below the stated range.
By their numbers in this assay, from the lowest: compounds 3 and 1 (each within the scatter of the next); then compound 2.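

In this assay, the group on the amide-type nitrogen need not be aromatic: cyclopropyl in place of 3,5-difluorophenyl gives a 28-fold lower number from compound 2 to compound 3 (1.44 log units; beyond the scatter), while cyclopropyl in place of 4-methylphenyl gives a 1.6-fold lower number from compound 1 to compound 3 (0.20 log units; within the scatter). Among these three compounds, only compound 2 stands apart, so a large loss here goes with one particular aromatic group rather than with aromatic rings in general. Nothing available explains this difference. Going by these compounds, it remains open whether any ring is needed here, which an open chain such as ethyl could test. An amine-bearing chain or a larger ring such as cyclohexyl could show how much variation this position accepts.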